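The compounds below may be only part of what the source reports. "The series", "measured", "known", "first", "only" and "open" are said of these compounds alone.

Three measured compounds share one core and were tested in a functional assay on SK-OV-3 cells (Homo sapiens) for antiproliferative activity, read by MTT assay, with a stated time of 72 h; a higher number here means a weaker inhibitor, a lower number a stronger inhibitor. Compound 1 `COc1ccc(NC(=O)CCc2cccc3c2B(O)OC3)cc1OC` reaches only the limit > 100000 nM in this assay, so it gives no number, only the edge of what the test reports (the limit of > 100000 nM in this assay, at which 1 of the 3 values shown sits). Compound 2 `O=C(CCc1cccc2c1B(O)OC2)Nc1cccc2ccccc12` gives 170 nM in this assay. Compound 3 `O=C(CCc1cccc2c1B(O)OC2)Nc1cccc(-c2cccc(F)c2)c1`, which carries a 3-fluorophenyl group, gives 480 nM in this assay. Of the two numbers, compound 3 stands highest; compound 2 is its nearest neighbour, and its lower number lies beyond the usual scatter, so compound 2 is the stronger inhibitor of the two.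

Compound 4 `O=C(CCc1cccc2c1B(O)OC2)Nc1cccc(-c2ccc(C(F)(F)F)cc2)c1` has not yet been measured. It differs from compound 3 in one place: 4-(trifluoromethyl)phenyl in place of 3-fluorophenyl on an aromatic carbon. Going by the values given here, no measured pair shows what such a swap does, so the expectation rests on compound 3 alone. The 3-fluorophenyl group leaves and a 4-(trifluoromethyl)phenyl group enters at the same aromatic carbon; both are six-membered aromatic rings of carbon only with no donors or acceptors. A step of modest size is expected, around the scatter, if anything toward a weaker inhibitor. Compound 4 is expected to give 650 nM in this assay, within 220 nM to 2000 nM, which means an expected step of a 1.4-fold higher number from compound 3 to compound 4 (0.13 log units; within the scatter).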

Compound 4, half-maximal inhibitory concentration: 500 nM
The estimate for compound 4 lay 1.3-fold (0.11 log units) above the measured number, and the stated range covers the measured number.
By their numbers in this assay, from the lowest: compound 2; then compounds 3 and 4 (each within the scatter of the next). At a limit, above all of these: compound 1.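

In this assay, going by these compounds alone, the swap gives a 1.0-fold higher number from compound 3 to compound 4 (0.02 log units; within the scatter), the first direct view of a change at this aromatic carbon, since no earlier pair of compounds differed in only one place. The number therefore holds when a group gives way to one with more heavy atoms, at least for these two rings, each a six-membered aromatic ring of carbon only and meta to a large group. No measurement shown here bears on why the number holds through this swap.

This single pair replaces 3-fluorophenyl with 4-(trifluoromethyl)phenyl in one move, so it leaves open what the change of group and the change of its place on the ring would each do alone. Also open, on these data alone, is whether this aromatic carbon tolerates something of a different kind, such as an amine, a carboxylic acid or a longer chain, since both groups compared here have no hydrogen-bond donors or acceptors and no net charge.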